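Fluoro for Bromo on the Shared Core, Before Measurement

The source may report more compounds than this note shows. Statements on the series, on what has been measured and on what is new or still open speak of the compounds shown alone.

Measured compounds:
compound 1 `O=C1NC(=S)/C(=C/c2ccc(Cl)cc2)S1`: 16.1%
compound 2 `O=C1NC(=S)/C(=C/c2ccccc2Br)S1`: 16.2%
compound 3 `O=C1NC(=S)/C(=C/c2cccc(Cl)c2)S1`: 17.6%

Of the compounds shown here, three on the shared core have been tested in a functional assay on HEp-2 cells (Homo sapiens) for cytotoxicity, read by MTT assay, with a stated time of 72 h, tested at 5 ug/mL; on this read-out lower numbers stand for less inhibition of growth and higher numbers for more inhibition of growth at the one concentration tested. Compound 1 gives 16.1%, compound 2 gives 16.2% and compound 3 gives 17.6%. The number for compound 2 falls between those of compound 1 and compound 3, but all three lie within the usual scatter of one another, so no one of them can be set apart from the rest.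

Compound 4 `O=C1NC(=S)/C(=C/c2ccccc2F)S1` is not yet measured. It differs from compound 2 by fluoro in place of bromo on an aromatic carbon. For the measured compounds named here, no pair among the measured compounds differs in one place only, so there is no single-change step from which to read the size of such a swap; what is known is that the three halogen-bearing compounds sit close together.

On that basis the step of a number 0.2 percentage points lower from compound 2 to compound 4 (within the scatter) is expected to be none beyond the scatter. Compound 4 is estimated to give 16%, in a range from 7% to 26%.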

Compound 4, percent growth inhibition at one concentration: 8.86%
Compound 4: the middle estimate sits 7.1 percentage points above what was measured, and the stated range covers the measured number.
By their numbers in this assay, from the lowest: compounds 4, 1, 2 and 3 (each within the scatter of the next).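

For the compounds shown here, the step of a number 7.3 percentage points lower from compound 2 to compound 4 (within the scatter), read in this assay, is the first on the shared core that isolates one change: fluoro in place of bromo on an aromatic carbon, ortho to a group of 8 heavy atoms. Going by these compounds alone, it shows that at this position, exchanging one halogen atom for another does not take the number beyond the scatter, something the earlier compounds, which differ from one another in more than one place, could not show. No measurement available here bears on this result, and the step stands without an explanation.

The compounds shown leave open whether an amine or a methoxy group at this same place would take the number beyond the scatter. They also leave open whether the same swap elsewhere on the aromatic ring would give a step of similar size.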